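The source may report more compounds than this note shows. Statements on the series, on what has been measured and on what is new or still open speak of the compounds shown alone.

Measured so far in a functional assay on Jurkat cells (Homo sapiens) for activation, with a stated time of 24 h; on this read-out lower numbers stand for an effect already at smaller amounts and higher numbers for an effect only at larger amounts of compound:

compound 1 `Oc1ccccc1CNc1ccc(-c2ccccc2)cc1`: 1820 nM
compound 2 `CC(C)Oc1ccc(-c2ccc(NCc3ccccc3O)cc2)cc1`: 5940 nM

Compound 2 stands highest of the two numbers in this assay, the nearest being compound 1. For the measured compounds named here, the single measured step, a 3.3-fold higher number from compound 1 to compound 2 (0.51 log units; beyond the scatter), was modest and beyond the scatter. Compound 3 `CCCc1ccc(-c2ccc(NCc3ccccc3O)cc2)cc1` differs from compound 2 by propyl in place of isopropoxy on an aromatic carbon. Going by the values given here, no measured step compares propyl with isopropoxy at this aromatic carbon; the step of a 3.3-fold higher number from compound 1 to compound 2 (0.51 log units; beyond the scatter) bears on it only indirectly, since compound 2 and compound 3 both carry a group there. The expected step is therefore small, a 1.3-fold lower number from compound 2 to compound 3 (0.12 log units; within the scatter), within the scatter. Compound 3 is estimated at 4500 nM, with a range from 1800 nM to 11000 nM.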

Compound 3, half-maximal effective concentration: 2390 nM
Beside the measured number, compound 3's estimate is 1.9-fold (0.27 log units) above it, within the range that was stated.
By their numbers in this assay, from the lowest: compounds 1 and 3 (each within the scatter of the next); then compound 2.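

In this assay the change from isopropoxy to propyl on this aromatic carbon gives a 2.5-fold lower number from compound 2 to compound 3 (0.40 log units; beyond the scatter), so the higher number of compound 2 does not come with every group placed here. Propyl in place of hydrogen gives a 1.3-fold higher number from compound 1 to compound 3 (0.12 log units; within the scatter), which does not separate the two compounds. Nothing given here accounts for the difference between isopropoxy and propyl.

The compounds shown leave open whether the oxygen or the branching of isopropoxy goes with the higher number, which propoxy or isopropyl here would address. As far as these compounds go, how an amine or a longer chain would read also remains open.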